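A few compounds are considered here, and "the series" means these few. Any claim that something is new, unique, unknown or untested is made for them only; others in the source may bear on it.

Compound 1 `Cc1cc(C)c(Oc2cc(Nc3ccc(C#N)cc3)ncc2C(=O)NCc2cn(Cc3ccccc3C#N)nn2)c(C)c1` in an ADME assay on MT4 cells (Homo sapiens) for cytotoxicity, read by MTT assay, with a stated time of 5 days (a higher number here means that more compound is tolerated, a lower number that less compound is tolerated), gives > 219000 nM, a limit of the assay. Compound 2 `CC(=O)Cn1cc(CNC(=O)c2cnc(Nc3ccc(C#N)cc3)cc2Oc2c(C)cc(C)cc2C)nn1` gives 19400 nM in this assay. Compound 3 `Cc1cc(C)c(Oc2cc(Nc3ccc(C#N)cc3)ncc2C(=O)NCc2cn(Cc3ccc([N+](=O)[O-])cc3)nn2)c(C)c1` gives >= 139000 nM in this assay, also a limit.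

Compound 1 thus stands only at a limit; of the three values shown, two are limits the limit of > 219000 nM in this assay, at which 1 of the 3 values shown sits (the limit of >= 139000 nM in this assay, at which 1 of the 3 values shown sits). Compound 4 `Cc1cc(C)c(Oc2cc(Nc3ccc(C#N)cc3)ncc2C(=O)NCc2cn(CC(=O)N3CCOCC3)nn2)c(C)c1` is not yet measured; it differs from compound 1 as follows: (morpholin-4-yl)carbonyl in place of 2-cyanophenyl on a saturated chain carbon bound to an aromatic nitrogen. The closest measured step is an at least 11-fold lower number from compound 1 to compound 2 (1.05 log units; beyond the scatter), where a carbonyl-bearing chain also enters at the same place. The step that the two limits leave unreadable from compound 1 to compound 3 cannot be read from its two limits, while an at least 7.1-fold higher number from compound 2 to compound 3 (0.85 log units; beyond the scatter) points the other way. A lower number is therefore expected for compound 4, as estimated at an at least 3.6-fold lower number from compound 1 to compound 4 (0.56 log units; beyond the scatter). Compound 4 is expected at 60000 nM, within 15000 nM to 219000 nM.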

Compound 4, half-maximal cytotoxic concentration: 181000 nM
Estimate against measurement, compound 4: 3.0-fold (0.48 log units) below, and the stated range covers the measured number.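

At the saturated chain carbon bound to an aromatic nitrogen, a carbonyl on the chain does not by itself lower the number in this assay: morpholin-4-yl in place of methyl on the carbonyl carbon gives a 9.3-fold higher number from compound 2 to compound 4 (0.97 log units; beyond the scatter). The value of compound 1 is a limit, so the change from 2-cyanophenyl yields only a floor, an at least 1.2-fold lower number from compound 1 to compound 4 (0.08 log units; that floor lies within the scatter). The step between compound 3 and compound 4 cannot be read.

Open, on these data alone, is whether the higher number belongs to the morpholin-4-yl ring or to any nitrogen on the carbonyl carbon. A dimethylamino group or a carboxylic acid there would separate these.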